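Adding a Second Chloro to the Pyridine Ether

A few compounds are considered here, and "the series" means these few. Any claim that something is new, unique, unknown or untested is made for them only; others in the source may bear on it.

Measured compounds in a functional assay for agonist activity at Free fatty acid receptor 1 (Homo sapiens), read by FLIPR, in the presence of a further agent that is not named here; a higher number here means that more compound is needed for the effect, a lower number that less compound is needed:
compound 1 `Cc1ccnc(Oc2ccc(CC3SC(=O)NC3=O)cc2)c1`: 4280 nM
compound 2 `O=C1NC(=O)C(Cc2ccc(Oc3ccc(Cl)cn3)cc2)S1`: 1870 nM
compound 3 `Cc1ccccc1Oc1ccc(CC2SC(=O)NC2=O)cc1`: 124 nM

Compound 2 stands second highest of the three numbers in this assay. Its nearest neighbour is compound 1, with a 2.3-fold lower number from compound 1 to compound 2 (0.36 log units; beyond the scatter) between them; its furthest is compound 3, with a 15-fold lower number from compound 2 to compound 3 (1.18 log units; beyond the scatter).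

Compound 4 `O=C1NC(=O)C(Cc2ccc(Oc3ncc(Cl)cc3Cl)cc2)S1` has not yet been measured. It differs from compound 2 in one place: chloro in place of hydrogen on an aromatic carbon.

Among the compounds with values here, no measured step isolates this change. Within the data shown here, two steps bear on it indirectly. The step of a 2.3-fold lower number from compound 1 to compound 2 (0.36 log units; beyond the scatter) shows that exchanging one small substituent for a chloro on the pyridine ring moves the number only modestly. The steps of a 35-fold lower number from compound 1 to compound 3 (1.54 log units; beyond the scatter) and a 15-fold lower number from compound 2 to compound 3 (1.18 log units; beyond the scatter) show that the largest gains come when the pyridine ring is replaced by a 2-methylphenyl group, which carries its small substituent ortho to the ether oxygen; compound 4 likewise places a chloro ortto to the large group, but keeps the pyridine ring. Compound 4 is therefore expected to give a modestly lower number than compound 2, with a 2.1-fold lower number from compound 2 to compound 4 (0.32 log units; beyond the scatter), well short of compound 3. The estimate for compound 4 is 900 nM, within a range of 300 nM to 2800 nM.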

Compound 4, half-maximal effective concentration: 90 nM
Estimate against measurement, compound 4: 10-fold (1.00 log units) above; measured number outside the range, below it.
By their numbers in this assay, from the lowest: compounds 4 and 3 (each within the scatter of the next); then compound 2; then compound 1.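

In this assay, one chloro in place of hydrogen, ortho to a large group and two atoms from the ring nitrogen, gives a 21-fold lower number from compound 2 to compound 4 (1.32 log units; beyond the scatter). Among the earlier compounds, the large steps came only with 2-methylphenyl in place of a pyridine ring, while the one exchange on the pyridine ring gave the modest 2.3-fold lower number from compound 1 to compound 2 (0.36 log units; beyond the scatter); the new step shows that a large change can also come with the ring nitrogen kept, from a single added heavy atom at this position. Nothing available here explains why this position responds so strongly.

The compounds shown leave open whether the gain is specific to chloro, or whether a fluoro, a methoxy or a nitrile at the same position would move the number as far. Within the data shown here, they also leave open whether the new chloro would give a step of this size without the chloro already on the ring, since it has been seen only in the presence of that group.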